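This account rests on a few compounds, and the source may have more. Where it says the series, first, only, none or still open, it means among the compounds named here.

Compound 1 `Cc1nc(S(C)(=O)=O)ccc1Oc1ncnc(OC2CCN(C(=O)OC(C)(C)C#N)CC2)c1F`: in a functional assay on isolated protein for inhibition of Glucose-dependent insulinotropic receptor (Homo sapiens), read by HTRF and cAMP accumulation (a lower number here means that less compound is needed, a higher number that more compound is needed for the effect), compound 1 gives 92.9 nM.
Compound 2 `Cc1nc(S(C)(=O)=O)ccc1Oc1ncnc(OC2CCN(C(=O)O[C@@H](C)CF)CC2)c1F`: in this assay compound 2 gives 186 nM.
Compound 3 `Cc1nc(S(C)(=O)=O)ccc1Oc1ncnc(OC2CCN(C(=O)C(F)(F)F)CC2)c1F`: in this assay compound 3 gives 151 nM.

All three compounds share the same core and differ only in the group attached to the carbonyl carbon on the ring nitrogen. Compound 3 sits close to both others: a 1.2-fold lower number from compound 2 to compound 3 (0.09 log units; within the scatter), and a 1.6-fold higher number from compound 1 to compound 3 (0.21 log units; within the scatter), so none of the three can be set apart from another.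

Compound 4 `Cc1nc(S(C)(=O)=O)ccc1Oc1ncnc(OC2CCN(C(=O)C3(C)CC3)CC2)c1F` continues this series of swaps at the same place: 1-methylcyclopropyl in place of trifluoromethyl on a carbonyl carbon. Within the data shown here, the steps already seen at that position are the only guide. Each of them, a 2.0-fold higher number from compound 1 to compound 2 (0.30 log units; within the scatter), a 1.6-fold higher number from compound 1 to compound 3 (0.21 log units; within the scatter) and a 1.2-fold lower number from compound 2 to compound 3 (0.09 log units; within the scatter), stayed within the scatter, even where the group changed considerably in its atoms and shape. A group of carbon only, with its small ring, is a further variation of the same kind, so in this assay no step beyond the scatter is expected, a 1.1-fold lower number from compound 3 to compound 4 (0.03 log units; within the scatter). Compound 4 is therefore estimated at 140 nM, with a range from 55 nM to 380 nM.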

Compound 4, half-maximal effective concentration: 761 nM
The estimate for compound 4 lay 5.4-fold (0.74 log units) below the measured number; measured number outside the range, above it.
By their numbers in this assay, from the lowest: compounds 1, 3 and 2 (each within the scatter of the next); then compound 4.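

Among these compounds, this position is not indifferent to the group placed on it: in this assay, the swap of trifluoromethyl for 1-methylcyclopropyl gives a 5.0-fold higher number from compound 3 to compound 4 (0.70 log units; beyond the scatter) and is the first change from compound 3 to pass beyond the scatter, even though both groups have 4 heavy atoms and neither has hydrogen-bond donors or acceptors. The other two comparisons agree, with a 4.1-fold higher number from compound 2 to compound 4 (0.61 log units; beyond the scatter) and an 8.2-fold higher number from compound 1 to compound 4 (0.91 log units; beyond the scatter), so among these four compounds only compound 4 separates from the rest. No measurement presented here accounts for this rise.

As far as these compounds go, the small ring and the carbon-only makeup of the group enter together in compound 4, so their separate contributions remain open. A plain cyclopropyl or tert-butyl group on the carbonyl carbon could help tell them apart.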